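From Pyridin-3-yl to Cycloheptyl on a Ring Amine Nitrogen

This account rests on a few compounds, and the source may have more. Where it says the series, first, only, none or still open, it means among the compounds named here.

Compound 1, `Nc1scc(CN2CCN(c3cccc(Cl)c3Cl)CC2)c1C(=O)c1ccc(Cl)cc1`: 0%
Compound 2, `Nc1scc(CN2CCN(c3cccnc3)CC2)c1C(=O)c1ccc(Cl)cc1`: 0%

In an assay on CHO cells for displacement of a labelled ligand from adenosine receptor A3 (Homo sapiens), read by scintillation counting, with a stated time of 120 min, tested at 10 uM (a higher number here means more inhibition at the concentration tested (going by the name of the read-out), a lower number less inhibition), compound 1 gives 0%. Compound 2 gives 0%, so compound 2 stands level with compound 1, as the step of no change at the digits printed from compound 1 to compound 2 (within the scatter) shows. Compound 3, `Nc1scc(CN2CCN(C3CCCCCC3)CC2)c1C(=O)c1ccc(Cl)cc1`, differs from compound 2 in one place: cycloheptyl in place of pyridin-3-yl on an amine nitrogen in a ring. Among the compounds with values here, no measured step exchanges an aromatic ring for a saturated one on this nitrogen; the only step known, no change at the digits printed from compound 1 to compound 2 (within the scatter), left the read-out unchanged. Compound 3 is therefore expected to show no step beyond the scatter, a number 3 percentage points higher from compound 2 to compound 3 (within the scatter). Compound 3 is estimated at 3%, within 0% to 20%.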

Compound 3, a percentage reported as inhibition, at one concentration (the size of the read-out at that concentration, not a potency): 0%
Compound 3: middle estimate off by 3 percentage points, on the high side, and the stated range covers the measured number.
By their numbers in this assay, from the lowest: compounds 1, 2 and 3 (each within the scatter of the next).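

In this assay, the change from an aromatic ring to a seven-membered carbon ring on this amine nitrogen gives no change at the digits printed from compound 2 to compound 3 (within the scatter) and no change at the digits printed from compound 1 to compound 3 (within the scatter) as well. Compounds 1, 2 and 3 therefore do not separate, whether the group on the nitrogen is aromatic or non-aromatic. No supporting data bear on why the read-out stays flat here. Still open, on these data alone, is whether a carboxylic acid, a primary amine or a longer alkyl chain on this nitrogen would give a different read-out, and whether a change elsewhere on the shared core would.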